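Methoxyphenyl for Chlorophenyl on Two Thiazole Amide Cores

This account rests on a few compounds, and the source may have more. Where it says the series, first, only, none or still open, it means among the compounds named here.

Compound 1 `COc1cc(-c2csc(NC(=O)c3ccc(Cl)cc3)n2)cc(OC)c1OC` and compound 2 `COc1cccc(C(=O)Nc2nc(-c3cc(OC)c(OC)c(OC)c3)cs2)c1` share one core, while compound 3 `COc1cc(-c2cs/c(=N\C(=O)c3ccc(Cl)cc3)n2C)cc(OC)c1OC` and compound 4 `COc1cccc(C(=O)/N=c2\scc(-c3cc(OC)c(OC)c(OC)c3)n2C)c1` share another; how the two cores differ is not broken down here. In a functional assay on MDA-MB-231 cells (Homo sapiens), read by microscopy and transwell migration, with a stated time of 24 h (a lower number here means a stronger inhibitor, a higher number a weaker inhibitor), compound 1 reaches only a limit, > 25000 nM, which is the limit of > 25000 nM in this assay, at which 1 of the 3 values shown sits. In this assay compound 2 gives 14000 nM, so the change 3-methoxyphenyl in place of 4-chlorophenyl on a carbonyl carbon produces an at least 1.7-fold lower number from compound 1 to compound 2 (0.25 log units; that floor lies within the scatter). In this assay, for the measured compounds named here, compound 3 gives 758 nM, the lowest number measured so far. Compound 4 carries the same change on the core of compound 3, namely (3-methoxyphenyl in place of 4-chlorophenyl on a carbonyl carbon). Compound 4 is expected to give 450 nM in this assay, an estimated step of a 1.7-fold lower number from compound 3 to compound 4 (0.23 log units; within the scatter), resting on the measured step of an at least 1.7-fold lower number from compound 1 to compound 2 (0.25 log units; that floor lies within the scatter), whose size is known only as a floor. The range expected for compound 4 runs from 150 nM to 1500 nM.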

Compound 4, half-maximal inhibitory concentration: > 50000 nM
Compound 4: a limit, no number (the forecaster's own chance of this, stated with the estimate: 2%); middle value at least 110-fold (2.04 log units) away from the limit.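

In this assay, 3-methoxyphenyl in place of 4-chlorophenyl on a carbonyl carbon gives an at least 65-fold higher number from compound 3 to compound 4 (1.81 log units; beyond the scatter), and the change does not behave alike on the two cores: the same change on two cores in this assay, an at least 1.7-fold lower number (0.25 log units; that floor lies within the scatter) from compound 1 to compound 2 and an at least 65-fold higher number (1.81 log units; beyond the scatter) from compound 3 to compound 4, at least 110-fold (2.07 log units) apart, beyond the scatter of two such steps. The size of this step is only a floor, since compound 4 stands at a limit of the assay: the limit of > 50000 nM in this assay, at which 1 of the 4 values shown sits. So the result of this change on the core of compound 1 did not carry over to the core of compound 3 in this assay, although a single pair on each core does not show why, or how other groups would behave.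

The compounds shown leave open how the core of compound 3 would respond to other groups on the phenyl ring at the carbonyl carbon, such as an amine or a carboxylic acid.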